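A few compounds are considered here, and "the series" means these few. Any claim that something is new, unique, unknown or untested is made for them only; others in the source may bear on it.

Working notes on the series. Compound 1 `O=C1NN(c2ccc([N+](=O)[O-])cc2)C(=O)C2(CSC3=C2C(=O)c2ncccc2C3=O)N1` and compound 2 `Cc1ccc(N2NC(=O)NC3(CSC4=C3C(=O)c3ncccc3C4=O)C2=O)cc1` share one core; compound 3 `O=C1C2=C(C(=O)c3ncccc31)C1(CS2)NC(=O)N(c2ccc([N+](=O)[O-])cc2)C1=O` and compound 4 `Cc1ccc(N2C(=O)NC3(CSC4=C3C(=O)c3ncccc3C4=O)C2=O)cc1` share another. How the core of compound 3 differs from that of compound 1 is not broken down here. In a functional assay on SF-268 cells (Homo sapiens) for antiproliferative activity, read by MTT assay, with a stated time of 96 h (a lower number here means a stronger inhibitor, a higher number a weaker inhibitor), compound 1 gives 3550 nM, compound 2 gives 2100 nM, and compound 3 gives 1520 nM. The change methyl in place of nitro on an aromatic carbon produced a 1.7-fold lower number from compound 1 to compound 2 (0.23 log units; within the scatter). The same change, (methyl in place of nitro on an aromatic carbon), is made from compound 3 to compound 4, at the same place on the aromatic ring. On the second core the expected step for compound 4 is a 1.7-fold lower number from compound 3 to compound 4 (0.23 log units; within the scatter), which rests on the measured step of a 1.7-fold lower number from compound 1 to compound 2 (0.23 log units; within the scatter). Compound 4 is therefore estimated at 900 nM, with a likely range from 400 nM to 2000 nM.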

Compound 4, half-maximal inhibitory concentration: 660 nM
The estimate for compound 4 lay 1.4-fold (0.13 log units) above the measured number; the range from low to high includes it.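

In this assay, methyl in place of nitro on the second core gives a 2.3-fold lower number from compound 3 to compound 4 (0.36 log units; beyond the scatter). Set beside the same change on the first core, the two steps do not differ: the same change on two cores in this assay, a 1.7-fold lower number (0.23 log units; within the scatter) from compound 1 to compound 2 and a 2.3-fold lower number (0.36 log units; beyond the scatter) from compound 3 to compound 4, 1.4-fold (0.13 log units) apart, within the scatter of two such steps. The change therefore carries across these two cores at a similar size, but this rests on one pair per core in a single assay, and it does not show why the number falls or that the step would hold on any other core.

Still open, going by these compounds, is whether an amine or a carboxylic acid in place of the methyl, at the same place on the aromatic ring, would give matching steps on both cores. A longer chain such as propyl raises the same question.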